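Triazole aryl variation on the spirooxindole core

The source may hold more compounds than are shown below. What is called first, only, known or untested is meant among the compounds shown, and "the series" means these compounds.

Measured so far in a functional assay on HepG2 cells (Homo sapiens) for antiproliferative activity, read by MTT assay, with a stated time of 48 h; on this read-out higher numbers stand for weaker inhibition and lower numbers for stronger inhibition:
compound 1 `CCc1ccccc1-n1nncc1CN1C(=O)C2(C(C#N)=C(N)Oc3c(N)cc4nc5ccccc5nc4c32)c2ccccc21`: 17900 nM
compound 2 `CCOc1ccc(-n2nncc2CN2C(=O)C3(C(C#N)=C(N)Oc4c(N)cc5nc6ccccc6nc5c43)c3ccccc32)cc1`: > 50000 nM
compound 3 `Cc1ccc(-n2nncc2CN2C(=O)C3(C(C#N)=C(N)Oc4c(N)cc5nc6ccccc6nc5c43)c3ccccc32)cc1C`: > 50000 nM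

The value of compound 2 is a limit of this assay, not a number. The value of compound 3 is likewise a limit, so compound 3 stands at the limit of > 50000 nM in this assay, at which 2 of the 3 values shown sit, with no readable number of its own. The steps of an at least 2.7-fold higher number from compound 1 to compound 2 (0.44 log units; beyond the scatter) and an at least 2.7-fold higher number from compound 1 to compound 3 (0.44 log units; beyond the scatter) both run toward weaker inhibition, while a step that the two limits leave unreadable from compound 2 to compound 3 cannot be read.

Compound 4 `N#CC1=C(N)Oc2c(N)cc3nc4ccccc4nc3c2C12C(=O)N(Cc1cnnn1-c1ccc(Cl)cc1[N+](=O)[O-])c1ccccc12` differs from compound 3 by 4-chloro-2-nitrophenyl in place of 3,4-dimethylphenyl on an aromatic nitrogen. For the measured compounds named here, no measured step bears on this change. For compound 4 the number in this assay is expected to stay near the limit, an estimate of 45000 nM (range 15000 nM to 150000 nM), meaning an estimated step of an at least 1.1-fold lower number from compound 3 to compound 4 (0.04 log units; that floor lies within the scatter).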

Compound 4, half-maximal inhibitory concentration: > 50000 nM
Compound 4 ended at the assay's limit; the forecaster's own chance of this, stated with the estimate: 60%; at least 1.1-fold (0.04 log units) between middle value and limit.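

In this assay compound 4 gives > 50000 nM as a limit of the assay and not a number. For the compounds shown here, a group named at the 2 position, as in 2-ethylphenyl, does not by itself keep a readable value: 4-chloro-2-nitrophenyl gives an at least 2.7-fold higher number from compound 1 to compound 4 (0.44 log units; beyond the scatter) and leaves compound 1 the only one with a number. The steps among compound 2, compound 3 and compound 4 cannot be read, and the series now piles up at one ceiling: the limit of > 50000 nM in this assay, at which 3 of the 4 values shown sit.

As far as these compounds go, whether an amine or a carboxylic acid on the aryl ring would bring values back into range stays open. So does whether a longer chain in place of the 2-ethyl group would do so.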